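Quinoline enones: heteroaryl ketone swap at the carbonyl

The source may report more compounds than this note shows. Statements on the series, on what has been measured and on what is new or still open speak of the compounds shown alone.

Measured so far in a functional assay on NCI-H1299 cells (Homo sapiens) for antiproliferative activity, read by XTT assay, with a stated time of 72 h; a lower number here means a stronger inhibitor, a higher number a weaker inhibitor:
compound 1 `COc1ccc(-c2cc3ccccc3nc2/C=C/C(=O)c2ccc(OC)cc2OC)cc1`: 3770 nM
compound 2 `COc1ccc(-c2cc3ccccc3nc2/C=C/C(=O)c2ccco2)cc1`: 730 nM

Compound 2 stands lowest of the two numbers; the nearest is compound 1, and the step of a 5.2-fold lower number from compound 1 to compound 2 (0.71 log units; beyond the scatter) shows how far apart the two sit. The next entry is compound 3 `COc1ccc(-c2cc3ccccc3nc2/C=C/C(=O)c2sccc2N)cc1`. Its difference from compound 2 is 3-aminothiophen-2-yl in place of furan-2-yl on a carbonyl carbon. For the measured compounds named here, the only measured step touching this position is the one from compound 1 to compound 2, which exchanged one aryl group on the carbonyl carbon for another and moved the number by the amount already given. Compound 3 keeps a five-membered aromatic ring at the same place, so a change of that size or smaller is the working assumption; direction is not fixed by the data, and a step within the scatter is expected, a 1.0-fold higher number from compound 2 to compound 3 (0.01 log units; within the scatter). For compound 3 in this assay the estimate is 750 nM, with a range from 250 nM to 2200 nM.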

Compound 3, half-maximal inhibitory concentration: > 10000 nM
Compound 3: only a limit was reported; the forecaster's own chance of this, stated with the estimate: 5%; middle value at least 13-fold (1.12 log units) from the limit.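

The swap on the carbonyl carbon gives an at least 13-fold higher number from compound 2 to compound 3 (1.13 log units; beyond the scatter), so in this assay keeping a five-membered aromatic ring at this place does not preserve the number. The 3-aminothiophen-2-yl group also compares poorly with the 2,4-dimethoxyphenyl group, with an at least 2.6-fold higher number from compound 1 to compound 3 (0.42 log units; beyond the scatter), so the six-membered ring of compound 1 is not the poorest group shown at this position. Compound 3 carries a limit rather than a number, so the true size of both steps remains open: the limit of > 10000 nM in this assay, at which 1 of the 3 values shown sits.

Compound 3 differs from compound 2 in both the ring hetero atom and the added amine, and the compounds shown do not separate these two changes. Thiophen-2-yl without the amine, or furan-2-yl carrying an amine, would show which change accounts for the step.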